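This account rests on a few compounds, and the source may have more. Where it says the series, first, only, none or still open, it means among the compounds named here.

Compound 2, with the structure `CC(C)n1c(=O)n(C(=O)NCCCN2CCN(C)CC2)c2ccccc21`, has been tested in a functional assay for antagonist activity at 5-hydroxytryptamine receptor 4 (Cavia porcellus); on this read-out lower numbers stand for lower potency and higher numbers for higher potency (the scale is a negative logarithm). In this assay compound 2 gives only a limit of the measurement, < 6, and not a number. Going by the values given here, compound 1, the structure `CC(C)n1c(=O)n(C(=O)NCCN2CCN(C)CC2)c2ccccc21`, is the one neighbour that differs from it in a single place. In this assay compound 1 likewise gives a limit, < 6. The step that the two limits leave unreadable from compound 1 to compound 2 cannot be read because the limit of < 6 in this assay, at which 2 of the 2 values shown sit, marks where both values sit. Compound 3, the structure `CCCN1CCN(CCNC(=O)n2c(=O)n(C(C)C)c3ccccc32)CC1`, has not yet been measured in this assay. It differs from compound 2 by 4-propylpiperazin-1-yl in place of (4-methylpiperazin-1-yl)methyl on a saturated chain carbon, two bonds along the chain from an amide-type nitrogen. Among the compounds with values here, no measured step shows what this exchange does, and both measured compounds sit at the limit, so the step in this assay is expected to be a step that the limit leaves unreadable from compound 2 to compound 3, with a real chance that only a limit is reported again. Compound 3 is therefore estimated at 5.5 in this assay, within the range 4.5 to 6.5.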

Compound 3, negative logarithm of the antagonist equilibrium constant: 6.89
Compound 3: middle estimate off by 1.39 log units, on the low side, and the stated range ends below it.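

In this assay, the change to 4-propylpiperazin-1-yl brings a measurable value: it gives a number at least 0.89 log units higher from compound 2 to compound 3 (beyond the scatter). Seen from compound 1, where the only change is ethyl in place of hydrogen on a saturated chain carbon bound to an amine nitrogen in a ring, the result is a number at least 0.89 log units higher from compound 1 to compound 3 (beyond the scatter). Going by these compounds alone, the step between compound 1 and compound 2 cannot be read, so this extension of the alkyl group on the piperazine ring is the first change here to show a clear rise in potency.

Going by these compounds, the full size of both rises stays open, because the values for compound 1 and compound 2 are limits and not numbers: the limit of < 6 in this assay, at which 2 of the 3 values shown sit. Whether a butyl or benzyl group in place of propyl would raise the value further also remains open.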